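Dimethylamino to Phenyl: Cytotoxicity Outlook for Compound 4

The source may report more compounds than this note shows. Statements on the series, on what has been measured and on what is new or still open speak of the compounds shown alone.

compound 1 `CCc1ncnc(NC(C)c2ccc(NC(C)=O)cc2)c1Cl`: in an ADME assay on HEK-293T cells (Homo sapiens) for cytotoxicity, with a stated time of 48 h (on this read-out lower numbers stand for higher toxicity in this test and higher numbers for lower toxicity in this test), compound 1 gives > 10000 nM, a limit of the assay.
compound 2 `CCc1ncnc(NC(CC)c2ccc([N+](=O)[O-])cc2)c1Cl`: compound 2 gives > 10000 nM, again a limit.
compound 3 `CCc1ncnc(NC(CC)c2ccc(N(C)C)cc2)c1Cl`: compound 3 gives > 10000 nM, also a limit.

Compound 3 therefore stands at the limit of this assay, as do the two other measured compounds (the limit of > 10000 nM in this assay, at which 3 of the 3 values shown sit). Among the compounds with values here, the only single-point step, a step that the two limits leave unreadable from compound 2 to compound 3, runs between two limits and its size cannot be read. Compound 4 `CCc1ncnc(NC(CC)c2ccc(-c3ccccc3)cc2)c1Cl` carries a different change: phenyl in place of dimethylamino on an aromatic carbon. Within the data shown here, no measured step bears on this change, so no direction beyond the scatter can be expected. The expectation is that compound 4 also sits at or past the limit, estimated at 15000 nM with a range from 5000 nM to 50000 nM. The step that the limit leaves unreadable from compound 3 to compound 4 is thus expected to be flat.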

Compound 4, half-maximal cytotoxic concentration: > 10000 nM
Compound 4 gave a limit, no number; the forecaster's own chance of this, stated with the estimate: 75%; the middle value lies beyond the limit too.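

Within the data shown here, compound 4, like compound 2 and compound 3, gives only a limit in this assay, so no new step among them can be read. The compounds shown leave open how far each lies past that limit.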